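Moving a chlorine around a ring on a shared aromatic core

The source may hold more compounds than are shown below. What is called first, only, known or untested is meant among the compounds shown, and "the series" means these compounds.

Of the compounds shown here, three built on one shared core have been measured in a functional assay on HCT-15 cells (Homo sapiens) for cytotoxicity, read by CCK-8 assay and cell counting, with a stated time of 2 days; a lower number here means a stronger inhibitor, a higher number a weaker inhibitor. Compound 1, `Oc1ccc(-c2cc(-c3ccc(Cl)cc3)nc(-c3ccsc3)c2)cc1`, gives 6240 nM. Compound 2, `Oc1ccc(-c2cc(-c3ccsc3)nc(-c3cccc(Cl)c3)c2)cc1`, gives 5760 nM. Compound 3, `Oc1ccc(-c2cc(-c3ccc(Cl)cc3)nc(-c3ccco3)c2)cc1`, gives 7020 nM. The change from compound 1 to compound 2 is 3-chlorophenyl in place of 4-chlorophenyl on an aromatic carbon, and it made a step of a 1.1-fold lower number from compound 1 to compound 2 (0.03 log units; within the scatter). The change from compound 1 to compound 3 is furan-2-yl in place of thiophen-3-yl on an aromatic carbon, with a step of a 1.1-fold higher number from compound 1 to compound 3 (0.05 log units; within the scatter). All three numbers lie within the scatter of one another, so none of them can be called stronger or weaker than the others.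

Compound 4, `Oc1ccc(-c2cc(-c3cccc(Cl)c3)nc(-c3ccco3)c2)cc1`, has not yet been measured. It differs from compound 3 by 3-chlorophenyl in place of 4-chlorophenyl on an aromatic carbon. Among the measured compounds shown here, this is the same kind of change as the one from compound 1 to compound 2, on a core whose difference is the one just described: in compound 3 and compound 4 the place is meta to a furan-2-yl group, whereas in compound 1 and compound 2 it is meta to a thiophen-3-yl group.

The step expected from this change is a 1.1-fold lower number from compound 3 to compound 4 (0.03 log units; within the scatter). This rests on compound 1 and compound 2, because a 1.1-fold lower number from compound 1 to compound 2 (0.03 log units; within the scatter) lies within the scatter, and nothing among these compounds suggests the furan-2-yl core would behave differently. Compound 4 is therefore expected to give 6500 nM in this assay, with a range from 3500 nM to 12000 nM.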

Compound 4, half-maximal inhibitory concentration: 8020 nM
Compound 4: the middle estimate sits 1.2-fold (0.09 log units) below what was measured, and the stated range covers the measured number.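

Going from 4-chlorophenyl to 3-chlorophenyl on the core bearing furan-2-yl gave a 1.1-fold higher number from compound 3 to compound 4 (0.06 log units; within the scatter) in this assay, and this agrees with the same change on the core bearing thiophen-3-yl: the same change on two cores in this assay, a 1.1-fold lower number (0.03 log units; within the scatter) from compound 1 to compound 2 and a 1.1-fold higher number (0.06 log units; within the scatter) from compound 3 to compound 4, 1.2-fold (0.09 log units) apart, within the scatter of two such steps Putting furan-2-yl in place of thiophen-3-yl with 3-chlorophenyl present gave a 1.4-fold higher number from compound 2 to compound 4 (0.14 log units; within the scatter), and this agrees with the same exchange made with 4-chlorophenyl present: the same change on two cores in this assay, a 1.1-fold higher number (0.05 log units; within the scatter) from compound 1 to compound 3 and a 1.4-fold higher number (0.14 log units; within the scatter) from compound 2 to compound 4, 1.2-fold (0.09 log units) apart, within the scatter of two such steps So both changes carry from one core to the other in the limited sense that neither does anything measurable on either core, but a change with no visible effect says nothing about whether a larger effect would carry over in the same way.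

The compounds shown leave open whether any change in this series can move the number beyond the scatter, since the 4-hydroxyphenyl group stays the same in all four and only the chlorine position and the furan-2-yl or thiophen-3-yl group vary. An amine or a carboxylic acid in place of the chlorine, or a methoxy group in place of the hydroxyl, would be a larger test of whether steps carry across these cores.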